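The compounds below may be only part of what the source reports. "The series", "measured", "known", "first", "only" and "open" are said of these compounds alone.

Compound 1 `Cc1ccccc1-c1cc(-c2ccoc2)cc(-c2ccc(Cl)s2)n1` gives 18500 nM
Compound 2 `Cc1cccc(-c2cc(-c3ccoc3)cc(-c3ccc(Cl)s3)n2)c1` gives 20300 nM
Compound 3 `Cc1ccc(-c2cc(-c3ccoc3)cc(-c3ccc(Cl)s3)n2)cc1` gives 25300 nM

All three values come from a functional assay on DU-145 cells (Homo sapiens) for cytotoxicity, read by ELISA, with a stated time of 4 days (a higher number here means a weaker inhibitor, a lower number a stronger inhibitor), and they cannot be told apart. Compound 3 stands level with the other two within the scatter (a 1.2-fold higher number from compound 2 to compound 3 (0.10 log units; within the scatter) and a 1.4-fold higher number from compound 1 to compound 3 (0.14 log units; within the scatter)). Compound 4 `Clc1cccc(-c2cc(-c3ccoc3)cc(-c3ccc(Cl)s3)n2)c1` differs from it in one exchange (3-chlorophenyl in place of 4-methylphenyl on an aromatic carbon), 3-chlorophenyl in place of 4-methylphenyl on an aromatic carbon. The measured steps, together with the third (a 1.1-fold higher number from compound 1 to compound 2 (0.04 log units; within the scatter)), only move a methyl group around the phenyl ring, and none exceeds the scatter. None of them exchanges methyl for chlorine, so the data give no direct measure of that swap. In this assay no step beyond the scatter is therefore expected (estimated: a 1.4-fold lower number from compound 3 to compound 4 (0.15 log units; within the scatter)). Compound 4 is expected at 18000 nM (estimated range 8000 nM to 35000 nM).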

Compound 4, half-maximal inhibitory concentration: 23000 nM
Compound 4: middle estimate off by 1.3-fold (0.11 log units), on the low side; the range from low to high includes it.
By their numbers in this assay, from the lowest: compounds 1, 2, 4 and 3 (each within the scatter of the next).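

In this assay, the direct exchange of chloro for methyl on the phenyl ring next to the ring nitrogen changes little (a 1.1-fold higher number from compound 2 to compound 4 (0.05 log units; within the scatter)). The 3-chlorophenyl group also stays level with the two other methylphenyl isomers (a 1.1-fold lower number from compound 3 to compound 4 (0.04 log units; within the scatter); a 1.2-fold higher number from compound 1 to compound 4 (0.09 log units; within the scatter)), so at this position chloro and methyl cannot be told apart. No supporting evidence bears on this result.

On these data alone, it remains open whether chloro at the other two phenyl positions would behave the same. As far as these compounds go, it also remains open whether an amine or a carboxylic acid on this phenyl ring would move the number beyond the scatter.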